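The source may report more compounds than this note shows. Statements on the series, on what has been measured and on what is new or still open speak of the compounds shown alone.

Compound 1 `O=C(CN(c1nc(Cl)nc2[nH]cnc12)C1CC1)N[C@@H](CO)C(=O)O` gives 39% in a functional assay on the whole organism (Tail, strain ICR) with Mus musculus as the target, in the tail flick test, with a stated time of 120 min, at a dose of 25 umol/kg by the oral route; on this read-out higher numbers stand for a stronger effect at the one dose given and lower numbers for a weaker effect.
Compound 2 `O=C(O)CC[C@H](NC(=O)CN(c1nc(Cl)nc2[nH]cnc12)C1CC1)C(=O)O` gives 30.1% in this assay.

Compound 2 holds the lower of the two numbers, yet its gap to compound 1 lies within the scatter, so the two are not separated. Compound 3 `C[C@@H](O)[C@H](NC(=O)CN(c1nc(Cl)nc2[nH]cnc12)C1CC1)C(=O)O` differs from compound 2 by 1-hydroxyethyl in place of 2-carboxyethyl on a saturated chain carbon bound to an amide-type nitrogen and a carbonyl carbon. Going by the values given here, the one measured step that bears on this, a number 8.9 percentage points lower from compound 1 to compound 2 (within the scatter), shows that swapping a hydroxy for a carboxymethyl on this chain carbon left the read-out essentially unchanged. Reversing toward a hydroxy-bearing group is therefore expected to give no step beyond the scatter in this assay. Compound 3 is estimated at 37%, within 22% to 52%, an expected step of a number 6.9 percentage points higher from compound 2 to compound 3 (within the scatter).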

Compound 3, a percentage reported as activity, at one dose (the size of the read-out at that dose, not a potency): 37.6%
Compound 3: middle estimate off by 0.6 percentage points, on the low side, within the range that was stated.
By their numbers in this assay, from the lowest: compounds 2, 3 and 1 (each within the scatter of the next).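

In this assay the change from 2-carboxyethyl to 1-hydroxyethyl gives a number 7.5 percentage points higher from compound 2 to compound 3 (within the scatter) while methyl in place of hydrogen on the hydroxy-bearing chain gives a number 1.4 percentage points lower from compound 1 to compound 3 (within the scatter) and neither step separates the compounds. At this chain carbon, the branched 1-hydroxyethyl group therefore stands level with both earlier side chains, and the three compounds form a single group on this read-out. Nothing given explains this outcome.
On these data alone, whether an amine, a phenyl ring or a longer chain at this chain carbon would move the read-out beyond the scatter remains open.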